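Methyl-for-hydrogen step on the alkoxy chain

The source may report more compounds than this note shows. Statements on the series, on what has been measured and on what is new or still open speak of the compounds shown alone.

Working notes on three brominated analogues and one untested successor. Compound 1, `CCc1cc(=O)c2ccc(OC)c(CBr)c2o1`, in a functional assay on A549 cells (Homo sapiens) for antiproliferative activity, read by sulforhodamine B assay, with a stated time of 72 h (a lower number here means a stronger inhibitor of growth, a higher number a weaker inhibitor of growth), gives > 33600 nM, which is a limit of the assay and not a number. Compound 2, `CCOc1ccc2c(=O)cc(CC)oc2c1CBr`, in this assay gives > 32100 nM, again a limit. Compound 3, `COc1ccc2c(=O)cc(C(C)Br)oc2c1CBr`, in this assay gives > 26500 nM, also a limit. Compound 3 therefore stands only at a limit, namely (the limit of > 26500 nM in this assay, at which 1 of the 3 values shown sits), and the two other values shown are likewise limits, the limit of > 32100 nM in this assay, at which 1 of the 3 values shown sits, and (the limit of > 33600 nM in this assay, at which 1 of the 3 values shown sits).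

Compound 4, `CCOc1ccc2c(=O)cc(C(C)Br)oc2c1CBr`, differs from compound 3 by methyl in place of hydrogen on a saturated chain carbon bound to an oxygen on an aromatic ring. The step that bears on it most directly is a step that the two limits leave unreadable from compound 1 to compound 2, since it is the same change made on compound 1. The step that the two limits leave unreadable from compound 1 to compound 3 connects compound 1 to compound 3 and is equally unreadable. Going by the values given here, with every value a limit and no step of readable size, no direction or size beyond the scatter can be read for the step to compound 4.

Compound 4 is accordingly expected to sit at a limit as well, estimated at 40000 nM with a range of 15000 nM to 120000 nM. The step this estimate means, a step that the limit leaves unreadable from compound 3 to compound 4, is expected to lie within the scatter.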

Compound 4, concentration for 50% growth inhibition: 19800 nM
Beside the measured number, compound 4's estimate is 2.0-fold (0.31 log units) above it; the measured number falls inside the stated range.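

In this assay, going by these compounds alone, compound 4 gives 19800 nM, the only number among the four compounds, and it is the first value for a compound that carries both the ethoxy group and the bromo on the saturated chain carbon bound to an aromatic carbon and a saturated chain carbon. Compound 1, compound 2 and compound 3 each stand at a limit of the assay. The methoxy to ethoxy change now has a floor, an at least 1.3-fold lower number from compound 3 to compound 4 (0.12 log units; that floor lies within the scatter), and the bromo-for-hydrogen change has one too, an at least 1.6-fold lower number from compound 2 to compound 4 (0.20 log units; that floor lies within the scatter), whereas the same two changes made on compound 1 remain unreadable. Both floors lie within the scatter, so neither change is shown to have a size beyond it, and the new finding is only that compound 4 alone gives a number rather than a limit.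

As far as these compounds go, the full size of either step stays open, as does whether a longer chain such as propoxy on the oxygen would move the number any further than ethoxy does. From the compounds shown here alone, it is equally open whether an amine in place of the bromo on the saturated chain carbon would keep a measurable value in this assay.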